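Swapping the aryl group on the sulfonyl sulfur

This account rests on a few compounds, and the source may have more. Where it says the series, first, only, none or still open, it means among the compounds named here.

compound 1 `O=S(=O)(Nc1ccc(-c2nc3ccccc3o2)cc1)c1ccccc1O`: > 100000 nM
compound 2 `O=S(=O)(Nc1ccc2oc(-c3ccccc3)nc2c1)c1ccccc1Cl`: 73000 nM
compound 3 `Cc1cccc(S(=O)(=O)Nc2ccc3oc(-c4ccccc4)nc3c2)c1`: 69000 nM

In an ADME assay on HEK293 cells (Homo sapiens) for cytotoxicity, read by resazurin assay, with a stated time of 48 h (on this read-out higher numbers stand for lower toxicity in this test and lower numbers for higher toxicity in this test), compound 1 gives > 100000 nM, which is a limit of the assay rather than a measured number, as recorded in the limit of > 100000 nM in this assay, at which 1 of the 3 values shown sits. Compound 2 gives 73000 nM and compound 3 gives 69000 nM. Within the data shown here, the only step between measured compounds, a 1.1-fold lower number from compound 2 to compound 3 (0.02 log units; within the scatter), also alters the group on the sulfonyl sulfur and stays within the scatter. Compound 4 `C=Cc1ccc(S(=O)(=O)Nc2ccc(-c3nc4ccccc4o3)cc2)cc1` awaits measurement in this assay. It differs from compound 1 by 4-vinylphenyl in place of 2-hydroxyphenyl on a sulfonyl sulfur. Among the measured compounds shown here, no measured step covers this particular exchange, and the one step that changes the group on the sulfonyl sulfur was within the scatter, so no shift beyond the scatter is expected. Compound 4 is therefore estimated at 100000 nM, in a range from 40000 nM to 300000 nM, an expected step of a number no higher from compound 1 to compound 4 (the limit leaves the size open).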

Compound 4, half-maximal cytotoxic concentration: > 100000 nM
Compound 4 was reported as a limit (the forecaster's own chance of this, stated with the estimate: 50%); the middle value sits exactly at the limit.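

Among these compounds, compound 1 and compound 4 are both reported only as a limit in this assay, so no step between them can be read: the limit of > 100000 nM in this assay, at which 2 of the 4 values shown sit. Going by these compounds, whether 4-vinylphenyl in place of 2-hydroxyphenyl on a sulfonyl sulfur shifts the read-out at all stays open.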